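Swapping Chloro for Methoxy on the Shared Core

The source may report more compounds than this note shows. Statements on the series, on what has been measured and on what is new or still open speak of the compounds shown alone.

Compound 1 `CCOC(=O)c1c(-c2cccc(Oc3ccccc3)c2)[nH]c2cc(Cl)c(OC)cc2c1=O` gives in an ADME assay on Raji cells (Homo sapiens) for cytotoxicity, read by luminescence, with a stated time of 72 h (on this read-out higher numbers stand for an effect only at larger amounts of compound and lower numbers for an effect already at smaller amounts), only a limit of the assay, > 21500 nM.
Compound 2 `CCOC(=O)c1c(-c2cccc(-c3ccccc3)c2)[nH]c2cc(Cl)c(Cl)cc2c1=O` gives in this assay only a limit, > 21500 nM.
Compound 3 `CCOC(=O)c1c(-c2cccc(Oc3ccccc3)c2)[nH]c2cc(Cl)c(Cl)cc2c1=O` gives in this assay only a limit, > 21500 nM.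

For the measured compounds named here, compound 3 therefore stands at the same place as both of its neighbours: every value here sits at the limit (the limit of > 21500 nM in this assay, at which 3 of the 3 values shown sit), and no compound has a measured number at all. The two steps that lead into compound 3, a step that the two limits leave unreadable from compound 1 to compound 3 and a step that the two limits leave unreadable from compound 2 to compound 3, cannot be read, since a step between two limits has no size.

Compound 4 `CCOC(=O)c1c(-c2cccc(Oc3ccccc3)c2)[nH]c2cc(OC)c(Cl)cc2c1=O` differs from compound 3 by methoxy in place of chloro on an aromatic carbon. Compound 1 carries a methoxy group on the same ring, at a different carbon, and still sits at the limit, so the measured compounds give no hint that a methoxy group at this ring brings the cells into reach of the compound.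

Because all three neighbours sit at the limit (the limit of > 21500 nM in this assay, at which 3 of the 3 values shown sit), the step from compound 3 to compound 4 is expected to be a step that the limit leaves unreadable from compound 3 to compound 4, that is, nothing readable. Compound 4 is expected to give again a limit rather than a number, with an estimate of 30000 nM and a range from 15000 nM to 100000 nM.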

Compound 4, half-maximal effective concentration: > 21500 nM
Compound 4 was reported as a limit (the forecaster's own chance of this, stated with the estimate: 85%); the middle value is on the limit's open side.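

Compound 4, like compound 3, gives only a limit and not a number, so the step between compound 3 and compound 4 has no readable size: the limit of > 21500 nM in this assay, at which 4 of the 4 values shown sit.

The compounds shown leave open at what concentration, if any, compounds 1 to 4 would give a measurable effect in this assay, and whether any change on the shared core would shift it.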